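The source may hold more compounds than are shown below. What is called first, only, known or untested is meant among the compounds shown, and "the series" means these compounds.

Compounds measured so far:
- compound 1 `Brc1ccc2[nH]c(-c3cn(-c4ccccc4)nc3-c3ccccc3)nc2c1`: 1760 nM
- compound 2 `Fc1ccc(-c2nn(-c3ccccc3)cc2-c2nc3cc(Cl)ccc3[nH]2)cc1`: 2770 nM
- compound 3 `Fc1ccc(-c2nn(-c3ccccc3)cc2-c2nc3cc(Br)ccc3[nH]2)cc1`: 4940 nM

These values come from a functional assay on HeLa cells (Homo sapiens) for antiproliferative activity, read by MTT assay, with a stated time of 48 h; a higher number here means a weaker inhibitor, a lower number a stronger inhibitor. Compound 3 gives 4940 nM, which is within the scatter of compound 2, as a 1.8-fold higher number from compound 2 to compound 3 (0.25 log units; within the scatter) shows. The gap to compound 1 is larger: a 2.8-fold higher number from compound 1 to compound 3 (0.45 log units; beyond the scatter).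

Compound 4 `O=C(OCc1ccccc1)c1ccc2[nH]c(-c3cn(-c4ccccc4)nc3-c3ccc(F)cc3)nc2c1` has benzyloxycarbonyl in place of bromo on an aromatic carbon. The closest measured change at this place is the halogen swap, a 1.8-fold higher number from compound 2 to compound 3 (0.25 log units; within the scatter). Among the compounds with values here, no measured compound carries a group of this size here, so the direction remains open and the range is wide. The expected change is a 1.2-fold lower number from compound 3 to compound 4 (0.09 log units; within the scatter), with no shift beyond the scatter anticipated. Compound 4 is estimated at 4000 nM, with an expected range of 1200 nM to 13000 nM.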

Compound 4, half-maximal inhibitory concentration: 23600 nM
Beside the measured number, compound 4's estimate is 5.9-fold (0.77 log units) below it; measured number above the stated range.
By their numbers in this assay, from the lowest: compounds 1, 2 and 3 (each within the scatter of the next, the first and the last beyond it); then compound 4.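

In this assay this aromatic carbon tolerates less than the halogen swap suggested, since that swap stayed within the scatter: benzyloxycarbonyl in place of bromo gives a 4.8-fold higher number from compound 3 to compound 4 (0.68 log units; beyond the scatter) and in place of chloro gives an 8.5-fold higher number from compound 2 to compound 4 (0.93 log units; beyond the scatter). Both steps lie beyond the scatter and point towards a weaker inhibitor. No supporting data bear on what lies behind this loss.

Still open, on these data alone, is whether the loss follows from the ester link or from its benzyl part. A carboxylic acid, a methyl ester or an amide at this carbon would separate the two.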